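The compounds below may be only part of what the source reports. "The series", "measured", "known", "first", "only" and "open" are said of these compounds alone.

Series notes, values in a functional assay on SiHa cells (Homo sapiens) for inhibition, read by CCK-8 assay, with a stated time of 72 h, tested at 10 uM; a lower number here means less inhibition of growth, a higher number more inhibition of growth at the concentration tested:
- compound 1 `CN(C)C(=O)c1cc2cnc(Nc3ccc(N)cn3)nc2n1C1CCCC1` - 61.5%
- compound 2 `CN(C)C(=O)c1cc2cnc(Nc3ccc(NC(=O)C4(C(=O)Nc5cccc(Cl)c5)CC4)cc3)nc2n1C1CCCC1` - 97.3%
- compound 3 `Nc1ccc(NC(=O)C2(C(=O)Nc3ccc(F)cc3)CC2)cc1F` - 36%

Compound 2 stands highest of the three, beyond the scatter from both compound 1 and compound 3. Still unmeasured is compound 4 `CN(C)C(=O)c1cc2cnc(Nc3ccc(NC(=O)C4(C(=O)Nc5cccc(Br)c5)CC4)cc3)nc2n1C1CCCC1`, which has bromo in place of chloro on an aromatic carbon of compound 2 bromo in place of chloro on an aromatic carbon and is otherwise unchanged. Among the measured compounds shown here, no step between measured compounds that differ in one place is available as a guide. With compound 2 at 97.3% as the reference and little room left upward, no step beyond the scatter is expected in this assay for this exchange. The estimated step of a number 1.3 percentage points lower from compound 2 to compound 4 (within the scatter) is small. The estimate for compound 4 is 96% (expected range 85% to 100%).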

Compound 4, percent growth inhibition at one concentration: 92.5%
Estimate against measurement, compound 4: 3.5 percentage points above, and the stated range covers the measured number.
By their numbers in this assay, from the lowest: compound 3; then compound 1; then compounds 4 and 2 (each within the scatter of the next).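

In this assay, among the compounds shown here, the change from 3-chlorophenyl to 3-bromophenyl gives a number 4.8 percentage points lower from compound 2 to compound 4 (within the scatter), the first step that can be read at this position. Growth inhibition at the concentration tested therefore holds with either halogen on this aromatic carbon, and the two compounds cannot be separated in this read-out. Nothing available explains this result.

Open, as far as these compounds go, is whether hydrogen, methyl, methoxy, an amine or a carboxylic acid in place of the halogen would keep this inhibition. Also open, from the compounds shown here alone, is whether moving the chloro elsewhere on the ring would do so.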